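A few compounds are considered here, and "the series" means these few. Any claim that something is new, unique, unknown or untested is made for them only; others in the source may bear on it.

Measured in an ADME assay on BHK-21 cells (Mesocricetus auratus) for cytotoxicity, read by MTT assay; a higher number here means that more compound is tolerated, a lower number that less compound is tolerated:
- compound 1 `CC(=O)c1ccc2c(c1)nc(-c1ccccc1)n2C1CCCCC1`: 100000 nM
- compound 2 `CC(=O)c1ccc2c(c1)nc(-c1ccoc1)n2C1CCCCC1`: 77000 nM

In this assay, compound 2 gives 77000 nM. Among the measured compounds shown here, the only other measured value, from compound 1, is 100000 nM, and the two lie within the scatter of each other.

Compound 3 `CC(=O)c1ccc2c(c1)nc(-c1ccccn1)n2C1CCCCC1` keeps the shared core and the cyclohexyl group of compound 2. It differs in one place, with pyridin-2-yl in place of furan-3-yl on an aromatic carbon.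

For the measured compounds named here, only one measured step bears on this change. It is a 1.3-fold lower number from compound 1 to compound 2 (0.11 log units; within the scatter), where furan-3-yl replaces phenyl on the same carbon. That exchange of one aromatic ring for another stayed within the scatter, so no step beyond the scatter is expected in this assay, and no direction is favoured. Going by the values given here, a single step is thin evidence, however, and no measured compound yet carries pyridin-2-yl, so the range is kept wide.

The expected step is a 1.1-fold higher number from compound 2 to compound 3 (0.04 log units; within the scatter).

For compound 3, the estimated value is 85000 nM, with an expected range of 40000 nM to 160000 nM.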

Compound 3, half-maximal cytotoxic concentration: >= 100000 nM
Compound 3 ended at the assay's limit (the forecaster's own chance of this, stated with the estimate: 25%); middle value at least 1.1-fold (0.07 log units) away from the limit.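

In this assay compound 3 gives >= 100000 nM, which is a limit of the assay and not a number. The earlier compounds had shown only phenyl and furan-3-yl on the carbon between two ring nitrogen atoms; pyridin-2-yl now adds a six-membered aromatic ring with a ring nitrogen there, and the change gives an at least 1.2-fold higher number from compound 2 to compound 3 (0.11 log units; that floor lies within the scatter), so a third aromatic ring at this position brings no drop in the number, though the true size of the rise remains unknown. Pyridin-2-yl in place of phenyl gives a number no lower from compound 1 to compound 3 (the limit leaves the size open), and the size of this step cannot be read, because the result rests on a limit: the limit of >= 100000 nM in this assay, at which 1 of the 3 values shown sits.

The compounds shown leave open how far compound 3 really lies from compound 2, and so whether these aromatic rings differ at all in this assay. They also leave open whether a group of another kind on this carbon, such as an amine, a carboxylic acid or a longer alkyl chain, would bring the number down to a value that can be read.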